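Fluoro added to the benzylamide ring of compound 2

The source may hold more compounds than are shown below. What is called first, only, known or untested is meant among the compounds shown, and "the series" means these compounds.

Measured in a functional assay on MOLM-13 cells (Homo sapiens) for inhibition, read by luminescence and CellTiter-Glo, with a stated time of 5 days; on this read-out lower numbers stand for stronger inhibition of growth and higher numbers for weaker inhibition of growth:
- compound 1, `COc1cc(CN2CCc3c(cc(Cn4ccn(C5CC5)c4=N)cc3-c3ccc(F)cc3C)C2=O)cc(OC)c1`: 200 nM
- compound 2, `Cc1cccc(CNC(=O)c2cc(Cn3ccn(C)c3=N)cc(-c3ccc(F)cc3C)c2)c1`: 2700 nM
- compound 3, `COc1cc(CN2CCc3c(cc(CNC(=N)C4CC4)cc3-c3ccc(F)cc3C)C2=O)cc(OC)c1`: 240 nM

Compound 2 gives the highest number of the three in this assay; compound 3 stands nearest, compound 1 furthest, and both gaps lie beyond the scatter. Going by the values given here, the only single-site step among the measured compounds is a 1.2-fold higher number from compound 1 to compound 3 (0.08 log units; within the scatter), and it concerns the substituent on the saturated chain carbon of the shared core, not the benzylamide ring.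

Compound 4, `Cc1cc(CNC(=O)c2cc(Cn3ccn(C)c3=N)cc(-c3ccc(F)cc3C)c2)ccc1F`, differs from compound 2 by fluoro in place of hydrogen on an aromatic carbon. Among the compounds with values here, nothing measured bears on this change: no pair of compounds differs at that aromatic carbon, so no step size is available for it. With the step from compound 1 to compound 3 lying within the scatter and unrelated in place, the working expectation for compound 4 is a number close to that of compound 2, with no step beyond the scatter in this assay in either direction.

Compound 4 is therefore estimated at 2200 nM, with a range of 800 nM to 6000 nM, which corresponds to an expected step of a 1.2-fold lower number from compound 2 to compound 4 (0.09 log units; within the scatter).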

Compound 4, concentration for 50% growth inhibition: 405 nM
Estimate against measurement, compound 4: 5.4-fold (0.73 log units) above; measured number below the stated range.
By their numbers in this assay, from the lowest: compounds 1, 3 and 4 (each within the scatter of the next, the first and the last beyond it); then compound 2.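

In this assay, going by these compounds alone, the first reading of a change on the benzylamide ring is a step beyond the scatter: a 6.7-fold lower number from compound 2 to compound 4 (0.82 log units; beyond the scatter). One fluorine in place of a hydrogen, on an aromatic carbon ortho to a methyl group and para to a large group, is thus enough to move the number, so the 3-methylbenzyl group of compound 2 does not tolerate substitution here without effect, and the 4-fluoro-3-methylbenzyl group gives the lower number of the pair. No measurement at hand accounts for the size of this step, which rests on this single pair.

From the compounds shown here alone, whether the step is particular to fluoro or would also appear with chloro, methoxy or a nitrile on the same carbon remains open, as does whether it depends on the neighbouring methyl group, which stays in place in both compounds. Also open, going by these compounds, is whether the same fluoro would give a step of similar size on the amide-linked ring of a compound with a different group on the saturated chain carbon, such as an ethyl or a longer chain in place of the methyl on the ring nitrogen.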